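Bromo in place of hydrogen on compound 2

The source may hold more compounds than are shown below. What is called first, only, known or untested is meant among the compounds shown, and "the series" means these compounds.

Of the compounds shown here, two have been tested so far. In a functional assay on PC-3 cells (Homo sapiens) for cytotoxicity, read by MTT assay, with a stated time of 48 h (on this read-out higher numbers stand for weaker inhibition and lower numbers for stronger inhibition), compound 1 `COc1ccc(C2CC(c3cc4ccccc4oc3=O)=NN2C(C)=O)cc1` is reported as "not active" (no number reported), with no number given. Among the measured compounds shown here, compound 2 `CC(=O)N1N=C(c2cc3ccccc3oc2=O)CC1c1ccc(O)cc1` gives 58.7 ug/mL, the only number, so it cannot yet be ranked numerically against any other compound.

Compound 3 `CC(=O)N1N=C(c2cc3c(Br)cccc3oc2=O)CC1c1ccc(O)cc1` differs from compound 2 in one place: bromo in place of hydrogen on an aromatic carbon. The change is bromo in place of hydrogen on an aromatic carbon, ortho to a fused ring and meta to a fused ring. For the measured compounds named here, no measured step gauges this change, so the expectation stays close to compound 2 at 58.7 ug/mL. The estimated step of a 1.3-fold lower number from compound 2 to compound 3 (0.12 log units; within the scatter) is slight, towards stronger inhibition in this assay, and is not expected to exceed the scatter. Compound 3 is estimated at 45 ug/mL, with an expected range of 18 ug/mL to 110 ug/mL.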

Compound 3, half-maximal inhibitory concentration: 38.8 ug/mL
Compound 3: middle estimate off by 1.2-fold (0.06 log units), on the high side, within the range that was stated.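

Among the compounds shown here, this is the first step that can be read. In this assay, bromo in place of hydrogen on an aromatic carbon, ortho to a fused ring and meta to a fused ring, gives a 1.5-fold lower number from compound 2 to compound 3 (0.18 log units; within the scatter), so the values of the two compounds cannot be told apart and this aromatic carbon carries the single bromine without a separation beyond the scatter. Nothing measured alongside these values speaks to the reason for this result.

Still open, going by these compounds, is whether an amine or a carboxylic acid on this same aromatic carbon would separate from compound 2 beyond the scatter. Also open, on these data alone, is whether bromo on the other aromatic carbons of that ring would read as it does in compound 3.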